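Anilide replacement on the shared core: outlook for compound 3

The source may hold more compounds than are shown below. What is called first, only, known or untested is meant among the compounds shown, and "the series" means these compounds.

Going by the values given here, compound 2 `CCCS(=O)(=O)Nc1ccc(-c2cc(=O)c3c(O)cc(OC)c(OC(C)C)c3o2)cc1` gives 2900 nM in a functional assay on CWR22R cells (Homo sapiens) for antiproliferative activity, read by MTT assay, with a stated time of 3 days (on this read-out higher numbers stand for weaker inhibition and lower numbers for stronger inhibition), the smaller number of the two measured so far, though only by a margin inside the scatter. Compound 1 `COc1cc(O)c2c(=O)cc(-c3ccc(NS(C)(=O)=O)cc3)oc2c1OC(C)C` gives 3800 nM in this assay, and the step of a 1.3-fold lower number from compound 1 to compound 2 (0.12 log units; within the scatter) tells that the two cannot be separated. Compound 3 `COc1cc(O)c2c(=O)cc(-c3ccc(NC(=O)N4CCN(C)CC4)cc3)oc2c1OC(C)C` is not yet measured. It differs from compound 2 by (4-methylpiperazin-1-yl)carbonyl in place of propylsulfonyl on a nitrogen on an aromatic ring. Among the compounds with values here, the only measured step, a 1.3-fold lower number from compound 1 to compound 2 (0.12 log units; within the scatter), concerns the chain on the sulfonyl sulfur and left the number essentially where it was; no measured pair exchanges the propylsulfonyl group itself, so that step offers little guidance here. With nothing pointing either way, compound 3 is expected to give about 3000 nM in this assay. The step of a 1.0-fold higher number from compound 2 to compound 3 (0.01 log units; within the scatter) is thus estimated as no larger than the scatter, with a broad expected range from 900 nM to 10000 nM.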

Compound 3, half-maximal inhibitory concentration: 8800 nM
Compound 3: the middle estimate sits 2.9-fold (0.47 log units) below what was measured; the measured number falls inside the stated range.
By their numbers in this assay, from the lowest: compounds 2 and 1 (each within the scatter of the next); then compound 3.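

Going by these compounds alone, exchanging the sulfonyl group on a nitrogen on an aromatic ring for (4-methylpiperazin-1-yl)carbonyl is the first change to move the number beyond the scatter in this assay, with a 3.0-fold higher number from compound 2 to compound 3 (0.48 log units; beyond the scatter) and a 2.3-fold higher number from compound 1 to compound 3 (0.36 log units; beyond the scatter) both modest and in the same direction. The group on this nitrogen therefore registers in this assay, whereas methyl and propyl on the sulfonyl sulfur could not be separated. No measurement at hand accounts for the shift.

The carbonyl and the 4-methylpiperazine ring enter together, so the compounds shown do not separate their contributions. As far as these compounds go, whether an acetyl group, a morpholine-4-carbonyl group or the bare amine on this nitrogen would sit with the two sulfonyl compounds or with compound 3 remains open.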